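Removing the Pyrrolidine Ring From a Weak Binder

The source may hold more compounds than are shown below. What is called first, only, known or untested is meant among the compounds shown, and "the series" means these compounds.

Of the compounds shown here, three sharing one core have been measured in an assay on isolated protein for inhibition of tyrosine-protein kinase receptor UFO (Homo sapiens), with a stated time of 1.5 h; on this read-out lower numbers stand for stronger inhibition and higher numbers for weaker inhibition. Compound 1 `Cn1cc(-c2n[nH]c3ccc(N[C@@H]4CCNC4)cc23)cn1` gives 37000 nM; compound 2 `Cn1cc(-c2n[nH]c3ccc(N[C@H]4CCNC4)cc23)cn1` gives 239000 nM; compound 3 `Cn1cc(-c2n[nH]c3ccc(NC4CCNC4)cc23)cn1`, drawn without a configuration at its saturated ring carbon, gives 132000 nM. Compound 3 thus stands second highest of the three numbers: the step of a 3.6-fold higher number from compound 1 to compound 3 (0.55 log units; beyond the scatter) lies beyond the scatter, whereas a 1.8-fold lower number from compound 2 to compound 3 (0.26 log units; within the scatter) does not, and a 6.5-fold higher number from compound 1 to compound 2 (0.81 log units; beyond the scatter) concerns the two drawn configurations alone (the fact that compounds 1 and 2 differ only in the configuration as drawn).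

Compound 4 `Cn1cc(-c2n[nH]c3ccc(N)cc23)cn1` differs from compound 3 by hydrogen in place of pyrrolidin-3-yl on a nitrogen on an aromatic ring. Among the compounds with values here, none of the measured steps bears on this change: each of them turns only on the configuration at the saturated ring carbon (the fact that one of compounds 1 and 3 is drawn with a defined configuration and the other without, at the place where they differ, (the fact that one of compounds 2 and 3 is drawn with a defined configuration and the other without, at the place where they differ)), and in compound 4 that whole ring is gone. Within the data shown here, with no comparable step available, the direction is uncertain, and the estimate leans toward a weaker number. Compound 4 is expected to give about 300000 nM, within a range from 60000 nM to 1500000 nM. That estimate corresponds to an expected step of a 2.3-fold higher number from compound 3 to compound 4 (0.36 log units; beyond the scatter).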

Compound 4, half-maximal inhibitory concentration: 8910 nM
Compound 4: the middle estimate sits 34-fold (1.53 log units) above what was measured; measured number below the stated range.
By their numbers in this assay, from the lowest: compound 4; then compound 1; then compounds 3 and 2 (each within the scatter of the next).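

In this assay, the pyrrolidin-3-yl on a nitrogen on an aromatic ring proves dispensable: hydrogen in its place gives a 15-fold lower number from compound 3 to compound 4 (1.17 log units; beyond the scatter), and likewise a 27-fold lower number from compound 2 to compound 4 (1.43 log units; beyond the scatter). Even compound 1, the lowest of the three ring-bearing compounds, does not match the plain amino compound, with a 4.2-fold lower number from compound 1 to compound 4 (0.62 log units; beyond the scatter), so at this position each drawn form of the ring goes with a higher number than hydrogen does. Nothing known about these compounds explains this change.

The compounds shown leave open whether any substituent on this nitrogen can give a lower number than hydrogen. A methyl, an acetyl or a 2-aminoethyl chain there would show whether the higher numbers go with the pyrrolidine ring in particular or with substitution on that nitrogen in general.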